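The source may report more compounds than this note shows. Statements on the series, on what has been measured and on what is new or still open speak of the compounds shown alone.

Measured in an ADME assay on BJ cells (Homo sapiens) for cytotoxicity, with a stated time of 72 h; a higher number here means that more compound is needed for the effect, a lower number that less compound is needed:
Compound 1 `COc1ccc(-c2nc3ccccc3o2)cc1NC(=O)c1cc([N+](=O)[O-])ccc1Cl`: > 25000 nM (a limit of the assay)
Compound 2 `O=C(Nc1nc(-c2cccc(F)c2)cs1)c1cc([N+](=O)[O-])ccc1Cl`: 24000 nM

Compound 1 gives > 25000 nM in this assay, which is a limit and not a number. Compound 3 `O=C(Nc1cc(-c2nc3ccccc3o2)ccc1F)c1cc([N+](=O)[O-])ccc1Cl` has fluoro in place of methoxy on an aromatic carbon, ortho to a large group and para to a 1,3-benzoxazol-2-yl group (fluoro in place of methoxy on an aromatic carbon). Among the measured compounds shown here, no measured step bears on this change, so a shift no larger than the usual scatter is expected, in neither direction. The estimated change is a number no higher from compound 1 to compound 3 (the limit leaves the size open). Compound 3 is expected at 25000 nM, with an estimated range of 12000 nM to 50000 nM.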

Compound 3, half-maximal effective concentration: > 25000 nM
Compound 3 was reported as a limit; the forecaster's own chance of this, stated with the estimate: 60%; the middle value sits exactly at the limit.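

No step can be read from compound 1 to compound 3 because both results are limits of the assay and not numbers: the limit of > 25000 nM in this assay, at which 2 of the 3 values shown sit. On these data alone, what fluoro in place of methoxy does to the value in this assay stays open.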